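Chain Variations on a Shared Benzimidazole Core and Histamine Inhibition

This account rests on a few compounds, and the source may have more. Where it says the series, first, only, none or still open, it means among the compounds named here.

Measured compounds:
compound 1, `CC(C)CCn1c(N2CCN(C)CC2)nc2ccccc21`: 1400 nM
compound 2, `CCNCCn1c(N2CCN(C)CC2)nc2ccccc21`: 290 nM
compound 3, `CCCSCn1c(N2CCN(C)CC2)nc2ccccc21`: 68 nM

In a functional assay on ileum for inhibition of histamine H1 receptor (Cavia porcellus) (a higher number here means a weaker inhibitor, a lower number a stronger inhibitor), compound 3 gives 68 nM, the lowest of the three numbers, and both steps that reach it lie beyond the scatter: a 21-fold lower number from compound 1 to compound 3 (1.31 log units; beyond the scatter) and a 4.3-fold lower number from compound 2 to compound 3 (0.63 log units; beyond the scatter). The step of a 4.8-fold lower number from compound 1 to compound 2 (0.68 log units; beyond the scatter) shows that a heteroatom placed in the chain already lowers the number before the sulfur-bearing chain is reached.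

Compound 4, `C#CCOCCn1c(N2CCN(C)CC2)nc2ccccc21`, departs from compound 3 by a single change: (propargyloxy)methyl in place of propylsulfanyl on a saturated chain carbon bound to an aromatic nitrogen. Going by the values given here, no measured step swaps one heteroatom-bearing chain for another of this kind, so the expectation rests only loosely on the two steps into compound 3, which both reward a chain carrying a heteroatom close to the aromatic nitrogen. Because a 4.3-fold lower number from compound 2 to compound 3 (0.63 log units; beyond the scatter) shows that exchanging one such chain for another can still move the number modestly, a modest shift is expected here, most likely toward a higher number, as a 2.2-fold higher number from compound 3 to compound 4 (0.34 log units; beyond the scatter). Compound 4 is estimated at 150 nM, within a range of 50 nM to 450 nM.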

Compound 4, half-maximal inhibitory concentration: 12 nM
Estimate against measurement, compound 4: 13-fold (1.10 log units) above, outside the stated range (below it).
By their numbers in this assay, from the lowest: compound 4; then compound 3; then compound 2; then compound 1.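

In this assay the 2-(propargyloxy)ethyl chain goes clearly past the sulfur-bearing chain, with a 5.7-fold lower number from compound 3 to compound 4 (0.75 log units; beyond the scatter), so exchanging one heteroatom-bearing chain for another at this place can still lower the number beyond the scatter. The same chain stands further still from the other two, with a 24-fold lower number from compound 2 to compound 4 (1.38 log units; beyond the scatter) and a 120-fold lower number from compound 1 to compound 4 (2.07 log units; beyond the scatter), which makes compound 4 the strongest inhibitor of the four, each of its steps lying beyond the scatter. Nothing measured here bears on why this chain has such an effect.

The compounds shown leave open whether the oxygen or the triple bond goes with the lower number, a question that a 2-propoxyethyl chain would separate. From the compounds shown here alone, how a longer ether chain or a terminal dimethylamine at this place would compare also remains open.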